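Methoxy to hydroxy at the far aryl of compound 3

The source may report more compounds than this note shows. Statements on the series, on what has been measured and on what is new or still open speak of the compounds shown alone.

Measured compounds:
compound 1, `COc1cc(C)cc(-c2nn(CC#N)cc2-c2ccc(-c3cccc(C(C)=O)c3)nc2)c1`: 3070 nM
compound 2, `Cc1cc(O)cc(-c2nn(CC#N)cc2-c2ccnc(-c3ccc(Oc4ccccc4)cc3)c2)c1`: 1170 nM
compound 3, `COc1cc(C)cc(-c2nn(CC#N)cc2-c2ccnc(-c3ccc(N(C)C)cc3)c2)c1`: 390 nM

In a functional assay on HOP-62 cells (Homo sapiens) for inhibition, read by sulforhodamine B assay, with a stated time of 48 h (a lower number here means a stronger inhibitor of growth, a higher number a weaker inhibitor of growth), compound 3 gives 390 nM, the lowest of the three numbers. Compound 2 stands nearest, with a number beyond the scatter above it, and compound 1 stands furthest, also beyond the scatter. Since compound 2 differs from compound 3 in more than one place and compound 1 differs at yet other places, none of the three pairs shows a single change, so the pairs only tell where each compound lies.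

Compound 4, `Cc1cc(O)cc(-c2nn(CC#N)cc2-c2ccnc(-c3ccc(N(C)C)cc3)c2)c1`, has not yet been measured in this assay. It differs from compound 3 by hydrogen in place of methyl on an oxygen on an aromatic ring. Going by the values given here, no measured pair isolates this change; compound 2 carries the hydroxy and compound 1 the methoxy, but both sit in different surroundings, so their numbers offer no step for it.

For compound 4 in this assay the change is expected to give a step of a 1.2-fold higher number from compound 3 to compound 4 (0.06 log units; within the scatter), that is, no clear move beyond the scatter in either direction. Compound 4 is therefore estimated at 450 nM, within a range of 150 nM to 1400 nM.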

Compound 4, concentration for 50% growth inhibition: 2820 nM
Beside the measured number, compound 4's estimate is 6.3-fold (0.80 log units) below it, outside the stated range (above it).
By their numbers in this assay, from the lowest: compound 3; then compound 2; then compounds 4 and 1 (each within the scatter of the next).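

In this assay, going by these compounds alone, the swap of methoxy to hydroxy on the 3-methoxy-5-methylphenyl group gives a 7.2-fold higher number from compound 3 to compound 4 (0.86 log units; beyond the scatter) and so provides the first reading of a single change at this place, showing that the methyl on this oxygen is not a silent feature of compound 3. With the hydroxy held constant, dimethylamino in place of phenoxy on an aromatic carbon gives a 2.4-fold higher number from compound 2 to compound 4 (0.38 log units; beyond the scatter) and moves the number the other way from what the low value of compound 3 might suggest, so dimethylamino does not bring a low number with the hydroxy present. The two changes therefore do not read independently of the surroundings in this small set, and nothing in the data at hand accounts for either step.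

As far as these compounds go, it remains open whether methoxy to hydroxy would give a step of similar size with phenoxy at the other end of the molecule, or whether the large step belongs to the dimethylamino series alone. Also open, from the compounds shown here alone, is whether the oxygen itself matters or only its capping group, a question that an ethoxy group or an amine at the same place on the aromatic ring would address.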